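A few compounds are considered here, and "the series" means these few. Any claim that something is new, unique, unknown or untested is made for them only; others in the source may bear on it.

Of the compounds shown here, three sharing one core have been tested in a functional assay on SW 1116 cells (Homo sapiens) for antiproliferative activity, read by MTT assay, with a stated time of 48 h; a lower number here means a stronger inhibitor, a higher number a weaker inhibitor. Compound 1 `Cc1ccc(N2CCN(Cn3nc(-c4ccc5c(c4)OCCO5)oc3=S)CC2)c(C)c1`, with 2,4-dimethylphenyl on the amine nitrogen in a ring, gives > 50000 nM, which is a limit of the assay and not a number. For the measured compounds named here, compound 2 `S=c1oc(-c2ccc3c(c2)OCCO3)nn1CN1CCN(c2cccc(Cl)c2Cl)CC1`, with 2,3-dichlorophenyl there, gives 37100 nM, the only true number so far. Compound 3 `S=c1oc(-c2ccc3c(c2)OCCO3)nn1CN1CCN(c2ccc(Cl)cc2)CC1`, with 4-chlorophenyl, gives > 50000 nM, and this too is a limit. Compound 3 therefore stands at the limit of > 50000 nM in this assay, at which 2 of the 3 values shown sit.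

Compound 4 `S=c1oc(-c2ccc3c(c2)OCCO3)nn1CN1CCN(c2cccc(Cl)c2)CC1` keeps the shared core and has 3-chlorophenyl in place of 4-chlorophenyl on an amine nitrogen in a ring. Going by the values given here, three measured steps bear on this change, all of them exchanges of the same aryl group. The closest is an at least 1.3-fold higher number from compound 2 to compound 3 (0.12 log units; that floor lies within the scatter). The second is an at least 1.3-fold lower number from compound 1 to compound 2 (0.12 log units; that floor lies within the scatter). The third is a step that the two limits leave unreadable from compound 1 to compound 3. None of them shows a change beyond the scatter, so no step beyond the scatter is expected in this assay, and compound 4 is expected to stay close to the limit. The estimated step is an at least 1.0-fold lower number from compound 3 to compound 4 (0.01 log units; that floor lies within the scatter). For compound 4 the estimated value is 48000 nM, with an expected range of 28000 nM to 80000 nM.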

Compound 4, half-maximal inhibitory concentration: > 50000 nM
Compound 4: a limit, no number; the forecaster's own chance of this, stated with the estimate: 55%; at least 1.0-fold (0.01 log units) between middle value and limit.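

In this assay compound 4 gives > 50000 nM and this is a limit of the assay and not a number. For the compounds shown here, the exchange of 4-chlorophenyl for 3-chlorophenyl on this amine nitrogen, like the exchange of 2,4-dimethylphenyl for 3-chlorophenyl, therefore gives a step that cannot be read, while the one readable step, with hydrogen in place of chloro on an aromatic carbon, is an at least 1.3-fold higher number from compound 2 to compound 4 (0.12 log units; that floor lies within the scatter) and so does not separate the 3-chlorophenyl group from the 2,3-dichlorophenyl group. Going by these compounds alone, with the chlorine at this other ring carbon the series gains no second true number, and compound 2 remains the only compound with one, so the set now reads: the limit of > 50000 nM in this assay, at which 3 of the 4 values shown sit.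

The compounds shown leave open how a plain phenyl, a methoxyphenyl or a pyridyl group on this amine nitrogen would read in this assay and whether any such group gives a step beyond the scatter. They also leave open whether 3-chlorophenyl and 4-chlorophenyl differ at all, as both lie at the limit of the assay.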